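Swapping the Aryl Ring for Methyl on the Shared Core

This account rests on a few compounds, and the source may have more. Where it says the series, first, only, none or still open, it means among the compounds named here.

Compound 1 `c1ccc(-c2nnc(-c3c[nH]c4ccccc34)o2)cc1` gives > 1000000 nM in a functional assay on LNCaP cells (Homo sapiens) for cytotoxicity, read by MTT assay (on this read-out lower numbers stand for stronger inhibition and higher numbers for weaker inhibition), which is a limit of this assay rather than a number.
Compound 2 `c1ccc2c(-c3nnc(-c4ccncc4)o3)c[nH]c2c1` gives 10000 nM in this assay.
Compound 3 `Clc1ccc(-c2nnc(-c3c[nH]c4ccccc34)o2)cc1` gives 583000 nM in this assay.

Compound 3 stands highest of the two numbers shown, and a 58-fold higher number from compound 2 to compound 3 (1.77 log units; beyond the scatter). Among the measured compounds shown here, the only other compound, compound 1, sits at the limit (the limit of > 1000000 nM in this assay, at which 1 of the 3 values shown sits). Compound 4 `Cc1nnc(-c2c[nH]c3ccccc23)o1` differs from compound 3 in one place: methyl in place of 4-chlorophenyl on an aromatic carbon. For the measured compounds named here, no measured step removes a whole ring; an at least 1.7-fold lower number from compound 1 to compound 3 (0.23 log units; that floor lies within the scatter) touches only a chloro group, while an at least 100-fold lower number from compound 1 to compound 2 (2.00 log units; beyond the scatter) exchanges one ring for another. For compound 4 a higher number, a 1.5-fold higher number from compound 3 to compound 4 (0.19 log units; within the scatter), is therefore expected, with a fair chance of reaching a limit. Compound 4 is estimated at 900000 nM, within 200000 nM to 4000000 nM.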

Compound 4, half-maximal inhibitory concentration: > 1000000 nM
Compound 4: only a limit was reported (the forecaster's own chance of this, stated with the estimate: 50%); at least 1.1-fold (0.04 log units) between middle value and limit.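

Compound 4, with methyl and no ring on this aromatic carbon, gives only a limit in this assay: the limit of > 1000000 nM in this assay, at which 2 of the 4 values shown sit.

The change to methyl shows an at least 1.7-fold higher number from compound 3 to compound 4 (0.23 log units; that floor lies within the scatter), so losing 4-chlorophenyl is not shown to matter, whereas losing pyridin-4-yl gives an at least 100-fold higher number from compound 2 to compound 4 (2.00 log units; beyond the scatter). Pyridin-4-yl alone stands apart here, against both aryl rings and methyl, and the step from compound 1 to compound 4 cannot be read.

From the compounds shown here alone, what a pyridin-3-yl ring or an amine on this carbon would give stays open, as does whether the ring nitrogen of pyridin-4-yl accounts for its lower number.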